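A few compounds are considered here, and "the series" means these few. Any claim that something is new, unique, unknown or untested is made for them only; others in the source may bear on it.

Values so far in a functional assay (trachea) with Cavia porcellus as the target; a higher number here means that more compound is needed for the effect, a lower number that less compound is needed
Compound 1 (`CCCn1c(=O)n(C)c(=O)c2[nH]cnc21`) gives 1600 nM
Compound 2 (`CCCn1c(=O)n(C)c(=O)c2c1ncn2CCOC`) gives 36100 nM

Compound 2 holds the higher of the two numbers, beyond the scatter from compound 1. Compound 3 (`CCCn1c(=O)n(C)c(=O)c2c1ncn2CC(C)=O`) carries acetyl in place of methoxymethyl on a saturated chain carbon bound to an aromatic nitrogen, so that 2-methoxyethyl becomes 2-oxopropyl acetyl in place of methoxymethyl on a saturated chain carbon bound to an aromatic nitrogen on the shared core. Among the measured compounds shown here, the only measured step is a 23-fold higher number from compound 1 to compound 2 (1.35 log units; beyond the scatter) and it is large, but it puts a chain onto the aromatic nitrogen rather than exchanging one chain for another. It therefore bears only loosely on compound 3, which keeps a chain there. For the measured compounds named here, no measured step covers such an exchange, so no step beyond the scatter is expected in this assay here. The estimated step is a 1.3-fold lower number from compound 2 to compound 3 (0.11 log units; within the scatter) and no more than that is expected. For compound 3 the estimate is 28000 nM with 9000 nM to 75000 nM as the expected range.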

Compound 3, half-maximal effective concentration: 1900 nM
Compound 3: middle estimate off by 15-fold (1.17 log units), on the high side; the whole stated range lies above it.
By their numbers in this assay, from the lowest: compounds 1 and 3 (each within the scatter of the next); then compound 2.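

In this assay, a chain on the aromatic nitrogen does not by itself carry the high number: 2-oxopropyl in place of 2-methoxyethyl gives a 19-fold lower number from compound 2 to compound 3 (1.28 log units; beyond the scatter), which nearly offsets the earlier 23-fold higher number from compound 1 to compound 2 (1.35 log units; beyond the scatter). Set against the hydrogen of compound 1, 2-oxopropyl gives a 1.2-fold higher number from compound 1 to compound 3 (0.07 log units; within the scatter), so compound 1 and compound 3 stand within the scatter of each other. Methoxymethyl and acetyl match in heavy atoms and hydrogen-bond acceptors, so these counts do not separate compound 2 from compound 3, and the large step goes with the exchange of the chain end at this position.

Open, going by these compounds, is whether the carbonyl itself is the decisive feature, which a 2-hydroxypropyl chain, an amine or a longer ketone chain on the same nitrogen could address. No measurement at hand accounts for the gap between the two chains.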